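Ester Variation on a Carbamate Oxygen in a Receptor Efficacy Series

This account rests on a few compounds, and the source may have more. Where it says the series, first, only, none or still open, it means among the compounds named here.

Measured compounds:
compound 1 `Cc1nc(S(C)(=O)=O)ccc1Oc1ncnc(OC2CCN(C(=O)OC(C)C)CC2)c1F`: 77%
compound 2 `Cc1nc(S(C)(=O)=O)ccc1Oc1ncnc(OC2CCN(C(=O)OC3CCC3)CC2)c1F`: 81%

In a functional assay on isolated protein for inhibition of Glucose-dependent insulinotropic receptor (Rattus norvegicus), read by HTRF and cAMP accumulation (a higher number here means a larger maximal response, a lower number a smaller maximal response), compound 2 gives 81%, while compound 1 gives 77%. Within the data shown here, the only step, a number 4 percentage points higher from compound 1 to compound 2 (within the scatter), lies within the scatter, so the two compounds cannot be told apart on the largest response reached; compound 2 simply stands as the compound with the cyclobutyl group.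

Compound 3 `Cc1nc(S(C)(=O)=O)ccc1Oc1ncnc(OC2CCN(C(=O)OC(C)(C)C(F)(F)F)CC2)c1F` carries the change (1-methyl-1-(trifluoromethyl)ethyl in place of cyclobutyl on an oxygen next to a carbonyl group). Among the measured compounds shown here, the one measured step that bears on this position, a number 4 percentage points higher from compound 1 to compound 2 (within the scatter), changed the group on the same oxygen and produced no shift beyond the scatter. On that single precedent, the new group in compound 3 is expected to leave the response roughly where compound 2 sits, with no step beyond the scatter in either direction. Compound 3 is therefore estimated at 78% in this assay, within 64% to 92%. This expectation amounts to a step of a number 3 percentage points lower from compound 2 to compound 3 (within the scatter).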

Compound 3, largest response reached (reported as efficacy), in percent of the reference or control that the assay uses: 79%
Compound 3: middle estimate off by 1 percentage points, on the low side; the measured number falls inside the stated range.
By their numbers in this assay, from the lowest: compounds 1, 3 and 2 (each within the scatter of the next).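

In this assay, the open-chain 1-methyl-1-(trifluoromethyl)ethyl group, with its 7 heavy atoms including 3 fluorine, replaces the four-membered carbon ring of cyclobutyl in a number 2 percentage points lower from compound 2 to compound 3 (within the scatter), and trifluoromethyl replaces hydrogen on the isopropyl group in a number 2 percentage points higher from compound 1 to compound 3 (within the scatter). Neither step leaves the scatter, so on this oxygen the largest response stays indistinguishable across a carbon ring, a branched carbon chain and a fluorine-bearing chain. No supporting measurement bears on why this response stays unchanged.

All three groups are compact, so the compounds leave open whether a phenyl ring or a longer chain ending in an amine on this oxygen would shift the response beyond the scatter. They also leave open whether a change elsewhere on the shared core would do so.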